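The source may hold more compounds than are shown below. What is called first, only, known or untested is meant among the compounds shown, and "the series" means these compounds.

Measured so far:
compound 1 `CNc1nc(-c2cc(OC)c(OC)c(OC)c2)c(-c2ccc3ccccc3c2)s1` gives 128 nM in a functional assay on HeLa cells (Homo sapiens) for antiproliferative activity, read by MTT assay, with a stated time of 72 h; a lower number here means a stronger inhibitor, a higher number a weaker inhibitor
compound 2 `COc1cc(-c2nc(N(C)C)sc2-c2ccc3ccccc3c2)cc(OC)c1OC` gives 1400 nM in this assay

Going by the values given here, compound 2 stands highest of these two numbers, and compound 1 is its only neighbour. The change to compound 3 `COc1cc(-c2nc(C)sc2-c2ccc3ccccc3c2)cc(OC)c1OC` is methyl in place of dimethylamino on an aromatic carbon and it falls on the same group of the shared core that separates the two measured compounds.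

Among the compounds with values here, the only measured step bearing on this is an 11-fold higher number from compound 1 to compound 2 (1.04 log units; beyond the scatter) and it is large and beyond the scatter. It consists of methyl in place of hydrogen on a nitrogen on an aromatic ring. Within the data shown here, no measured compound carries methyl on that aromatic carbon, so the direction rests on little evidence. A modest move toward a lower number is expected, smaller than the measured step, and a result within the scatter of compound 2 remains possible. The expected change is a 2.3-fold lower number from compound 2 to compound 3 (0.37 log units; beyond the scatter) in this assay as a rough estimate. The estimate for compound 3 is 600 nM with an expected range of 120 nM to 3000 nM for this value.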

Compound 3, half-maximal inhibitory concentration: 82.1 nM
Beside the measured number, compound 3's estimate is 7.3-fold (0.86 log units) above it; the whole stated range lies above it.
By their numbers in this assay, from the lowest: compounds 3 and 1 (each within the scatter of the next); then compound 2.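

In this assay, the step of a 17-fold lower number from compound 2 to compound 3 (1.23 log units; beyond the scatter) places dimethylamino apart from methyl on this aromatic carbon of the five-membered aromatic ring with 1 nitrogen and 1 sulfur, so the earlier penalty of an 11-fold higher number from compound 1 to compound 2 (1.04 log units; beyond the scatter) now has a second comparison on the same position. Going by these compounds alone, with a 1.6-fold lower number from compound 1 to compound 3 (0.19 log units; within the scatter) as the remaining step, methyl and methylamino cannot be separated here, and a nitrogen attached at this carbon is therefore not required for a value in the range of compound 1, which leaves dimethylamino as the only one of the three groups that stands apart. Nothing on hand explains why dimethylamino differs from the other two groups.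

Going by these compounds, whether the match between methyl and methylamino extends to an ethyl group, a primary amine or a methoxy group on this carbon remains open. Also open, on these data alone, is whether the same order of the three groups would hold with a phenyl group in place of the naphthalen-2-yl group.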